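Estimating Compound 4 from Three Measured Analogues

This account rests on a few compounds, and the source may have more. Where it says the series, first, only, none or still open, it means among the compounds named here.

Three compounds have numbers in a functional assay on MG-63 cells (Homo sapiens) for inhibition, read by CCK-8 assay, with a stated time of 72 h, tested at 1 uM; on this read-out higher numbers stand for more inhibition at the one concentration tested (going by the name of the read-out) and lower numbers for less inhibition. Compound 1 `COc1ccc(C)cc1N1C(=O)CSC1c1cccc(C(=O)NCCCCc2ccccc2)c1` gives 92%. Compound 2 `COc1ccccc1N1C(=O)CSC1C(=O)NCCCCc1ccccc1` gives 60%. Compound 3 `COc1ccc(F)cc1N1C(=O)CSC1c1cccc(C(=O)NCCCCc2ccccc2)c1` gives 86%, the second highest of the three; its nearest neighbour is compound 1, and the gap of a number 6 percentage points lower from compound 1 to compound 3 (within the scatter) lies within the scatter, whereas compound 2 sits far below it, beyond the scatter.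

Compound 4 `Cc1cccc(N2C(=O)CSC2c2cccc(C(=O)NCCCCc3ccccc3)c2)c1` differs from compound 3 in one place: 3-methylphenyl in place of 5-fluoro-2-methoxyphenyl on an amide-type nitrogen in a ring. Going by the values given here, the only measured step that touches the same aryl group, a number 6 percentage points lower from compound 1 to compound 3 (within the scatter), exchanged a single substituent on that ring and moved the read-out by less than the scatter. Compound 2 differs from compound 3 in more than one place, so its number offers no direct guide to this change. Because a number 6 percentage points lower from compound 1 to compound 3 (within the scatter) stayed within the scatter, the exchange of the whole aryl group in compound 4 is expected to shift the result in this assay only modestly, with a slight lean downward, and the expected step is a number 6 percentage points lower from compound 3 to compound 4 (within the scatter). Compound 4 is estimated at 80%, with a range from 62% to 94%.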

Compound 4, a percentage reported as inhibition, at one concentration (the size of the read-out at that concentration, not a potency): 93%
Compound 4: middle estimate off by 13 percentage points, on the low side; the measured number falls inside the stated range.
By their numbers in this assay, from the lowest: compound 2; then compounds 3, 1 and 4 (each within the scatter of the next).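

In this assay, exchanging the entire aryl group on the amide-type nitrogen in a ring, with 3-methylphenyl in place of 5-fluoro-2-methoxyphenyl, gives a number 7 percentage points higher from compound 3 to compound 4 (within the scatter) and so shows that this place accepts a change larger than the single-substituent exchange seen earlier without the read-out leaving the scatter. Going by these compounds alone, the narrower comparison, hydrogen in place of methoxy on an aromatic carbon, gives a number 1 percentage points higher from compound 1 to compound 4 (within the scatter) and shows for the first time that the methoxy group, carried by all three earlier compounds, can be absent with no step beyond the scatter in this assay. No measurement is available to explain why these exchanges leave the read-out within the scatter.

The compounds shown leave open whether this aryl ring would keep its read-out with an amine or a carboxylic acid in place of the methyl group, or with the whole ring replaced by a saturated cyclohexyl group. They also leave open whether compound 1, compound 3 and compound 4 would separate at lower concentrations, since a single tested concentration gives no potency.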